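This account rests on a few compounds, and the source may have more. Where it says the series, first, only, none or still open, it means among the compounds named here.

Measured so far in a functional assay on MKN-45 cells (Homo sapiens) for cytotoxicity, read by MTT assay, with a stated time of 72 h; a higher number here means a weaker inhibitor, a lower number a stronger inhibitor:
compound 1 `COc1cc2c(Oc3ccc(NC(=O)c4cc(-c5cccc(Cl)c5)nc5ccc(F)cc45)cc3F)ccnc2cc1OCCCN1CCC(C)CC1` gives 10 nM;
compound 2 `COc1cccc(-c2cc(C(=O)Nc3ccc(Oc4ccnc5cc(OCCCN6CCC(C)CC6)c(OC)cc45)c(F)c3)c3cc(F)ccc3n2)c1` gives 730 nM;
compound 3 `COc1cc2c(Oc3ccc(NC(=O)c4cc(-c5ccc(C)cc5)nc5ccc(F)cc45)cc3F)ccnc2cc1OCCCN1CCC(C)CC1` gives 260 nM.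

Compound 1 stands lowest of the three. The step to compound 3 is a 26-fold higher number from compound 1 to compound 3 (1.41 log units; beyond the scatter), and the step to compound 2 is a 73-fold higher number from compound 1 to compound 2 (1.86 log units; beyond the scatter); between those two, a 2.8-fold lower number from compound 2 to compound 3 (0.45 log units; beyond the scatter). All three steps alter the aromatic group hanging from the shared core of compound 1.

Compound 4 `COc1cc2c(Oc3ccc(NC(=O)c4cc(-c5cccc(Cl)c5)nc5ccc(F)cc45)cc3F)ccnc2cc1OCCCN1CCCC1` differs from compound 1 elsewhere: pyrrolidin-1-yl in place of 4-methylpiperidin-1-yl on a saturated chain carbon, three bonds along the chain from an oxygen on an aromatic ring. Among the compounds with values here, no measured step touches this part of the molecule, so there is nothing to show how much the amine ring matters. The expectation for this assay is therefore a step within the scatter, a 1.5-fold higher number from compound 1 to compound 4 (0.18 log units; within the scatter), with wider uncertainty than usual. Compound 4 is estimated at 15 nM, expected between 4 nM and 60 nM.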

Compound 4, half-maximal inhibitory concentration: 67 nM
Estimate against measurement, compound 4: 4.5-fold (0.65 log units) below, and the stated range ends below it.
By their numbers in this assay, from the lowest: compound 1; then compound 4; then compound 3; then compound 2.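

Within the data shown here, the amine ring at the end of the propyl chain, which no earlier step touched, does matter: in this assay, replacing 4-methylpiperidin-1-yl with pyrrolidin-1-yl gives a 6.7-fold higher number from compound 1 to compound 4 (0.83 log units; beyond the scatter), beyond the usual scatter. The activity of this series therefore depends on more than the aromatic group on the shared core. Nothing available explains this step.

The change shrinks the ring and loses the methyl together, so the compounds shown cannot separate those two differences. Going by these compounds, how a plain piperidin-1-yl or a morpholin-4-yl would read at this position remains open.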